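From Methoxy to Trifluoromethyl: an Expected Step

The source may hold more compounds than are shown below. What is called first, only, known or untested is meant among the compounds shown, and "the series" means these compounds.

Of the compounds shown here, three sharing one core have been measured in an assay on isolated protein for inhibition of N-acylethanolamine-hydrolyzing acid amidase (Homo sapiens), read by fluorescence, with a stated time of 90 min; a lower number here means a stronger inhibitor, a higher number a weaker inhibitor. Compound 1 `N#CN1CC(COCc2ccc(-c3ccccc3)cc2)C1` gives 3.4 nM. Compound 2 `COc1ccc(-c2ccc(COC3CN(C#N)C3)cc2)cc1` gives 0.94 nM, and compound 3 `COc1cccc(-c2ccc(COC3CN(C#N)C3)cc2)c1OC` gives 0.88 nM. On these numbers compound 2 stands second highest of the three; its nearest neighbour is compound 3, whose number differs by a margin that lies within the scatter, while compound 1 sits furthest away, with a number higher than that of compound 2 by a margin beyond the scatter.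

Compound 4 `N#CN1CC(OCc2ccc(-c3ccc(C(F)(F)F)cc3)cc2)C1` has not yet been measured. It differs from compound 2 in one place: trifluoromethyl in place of methoxy on an aromatic carbon, a trifluoromethyl in place of methoxy on an aromatic carbon, para to a large group. Among the measured compounds shown here, no single-change step between measured compounds covers this exchange. The measured compounds show that a substituent on that ring, as in compound 2 and compound 3, goes with a lower number than the unsubstituted compound 1, but nothing shows how trifluoromethyl compares with methoxy there. A modest step in either direction, or none beyond the scatter, seems the likeliest outcome. Compound 4 is therefore expected to give about 1.5 nM, between 0.5 nM and 5 nM. The expected step from compound 2 to compound 4 is a 1.6-fold higher number from compound 2 to compound 4 (0.20 log units; within the scatter), a small rise that is estimated to stay near the scatter.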

Compound 4, half-maximal inhibitory concentration: 1.6 nM
Compound 4: the middle estimate sits 1.1-fold (0.03 log units) below what was measured; measured number inside the range.
By their numbers in this assay, from the lowest: compounds 3, 2 and 4 (each within the scatter of the next); then compound 1.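

In this assay, among the compounds shown here, putting trifluoromethyl in place of methoxy on an aromatic carbon, para to a large group, gives a 1.7-fold higher number from compound 2 to compound 4 (0.23 log units; within the scatter), the first direct reading of any exchange at this place. Methoxy has 1 hydrogen-bond acceptor and trifluoromethyl has 0, and trifluoromethyl brings 4 heavy atoms where methoxy has 2, yet in this pair these differences come with no step beyond the scatter. No independent measurement is available to account for this result.

The compounds shown leave open whether an amine, a carboxylic acid or a longer chain such as butoxy at the same place would also stay within the scatter of compound 2. The exchange is also read from this single pair, so whether trifluoromethyl in place of methoxy would give a similar step elsewhere on the shared core, or alongside a second substituent on the same ring, remains an open question.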